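Dropping the Methyl from a Chlorinated Quinolinone

The source may report more compounds than this note shows. Statements on the series, on what has been measured and on what is new or still open speak of the compounds shown alone.

Compound 1, `Cc1ccc2[nH]c(=O)c(-c3nc4ccccc4[nH]3)cc2c1`, in a functional assay on NCI-H460 cells (Homo sapiens) for cytotoxicity, read by MTT assay, with a stated time of 48 h (a higher number here means a weaker inhibitor, a lower number a stronger inhibitor), gives a limit of > 100000 nM.
Compound 2, `Cc1ccc2[nH]c(=O)c(-c3nc4cc(Cl)ccc4[nH]3)cc2c1`, in this assay gives 36500 nM.
Compound 3, `COc1ccc2[nH]c(=O)c(-c3nc4cc(C)c(C)cc4[nH]3)cc2c1`, in this assay gives a limit of > 100000 nM.

For the measured compounds named here, compound 2 therefore holds the only numerical value in this assay; the other two results are limits. Going by the values given here, the one measured single-point step is an at least 2.7-fold lower number from compound 1 to compound 2 (0.43 log units; beyond the scatter), a step whose size is known only as a bound because of the limit of > 100000 nM in this assay, at which 2 of the 3 values shown sit. Compound 4, `O=c1[nH]c2ccccc2cc1-c1nc2cc(Cl)ccc2[nH]1`, differs from compound 2 by hydrogen in place of methyl on an aromatic carbon. Among the compounds with values here, no measured step concerns such a change, so the account carries no evidence on it, and no step beyond the scatter is expected in this assay. The expected step is a 1.1-fold higher number from compound 2 to compound 4 (0.04 log units; within the scatter). For compound 4 the estimate in this assay is 40000 nM, between 12000 nM and 100000 nM.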

Compound 4, half-maximal inhibitory concentration: 14700 nM
For compound 4 the middle estimate is 2.7-fold (0.43 log units) above the measured one, within the range that was stated.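

Hydrogen in place of methyl on this aromatic carbon gives a 2.5-fold lower number from compound 2 to compound 4 (0.39 log units; beyond the scatter), the first step at this position and the first in this assay with both ends measured as numbers. The methyl is therefore not required for the cytotoxicity seen with the chloro group present, and compound 4 is the stronger inhibitor of the two. Nothing measured here speaks to the cause of this step:.

The compounds shown leave open whether the same change would give a like step without the chloro group. They also leave open how an amine, a carboxylic acid or a longer chain would behave at this position.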